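The source may hold more compounds than are shown below. What is called first, only, known or untested is meant among the compounds shown, and "the series" means these compounds.

Of the compounds shown here, three have been measured in a functional assay on cells (Homo sapiens) for antiproliferative activity, read by sulforhodamine B assay, with a stated time of 5 days; a lower number here means a stronger inhibitor, a higher number a weaker inhibitor. Compound 3 `COc1cc(NC(=O)Nc2ccc(Cl)c(C(F)(F)F)c2)ccc1C` and compound 1 `Cc1ccc(NC(=O)Nc2ccc(Cl)c(C(F)(F)F)c2)cc1O` share one core and differ in a single spot: hydrogen in place of methyl on an oxygen on an aromatic ring In this assay compound 3 gives 2300 nM, while compound 1 gives 9500 nM. That one change made a step of a 4.1-fold higher number from compound 3 to compound 1 (0.62 log units; beyond the scatter), a step that lies beyond the usual scatter of repeated measurements. Compound 2 `COc1cc(NC(=O)Nc2cc(C(F)(F)F)cc(C(F)(F)F)c2)ccc1C` is built on a different core, and the difference between the core of compound 2 and the core of compound 3 is not broken down here. In this assay compound 2 gives 1800 nM, a number that sits within the scatter of the number for compound 3, so no order between the two can be claimed.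

Compound 4 `Cc1ccc(NC(=O)Nc2cc(C(F)(F)F)cc(C(F)(F)F)c2)cc1O` has not yet been measured. It stands to compound 2 exactly as compound 1 stands to compound 3: hydrogen in place of methyl on an oxygen on an aromatic ring The place of the change is described in the same words for both pairs, so this is the same change carried out on another core. Within the data shown here, only one measured example of this change exists, the step of a 4.1-fold higher number from compound 3 to compound 1 (0.62 log units; beyond the scatter), and the expectation rests on that example alone. On this basis the step from compound 2 to compound 4 is expected to be a 3.9-fold higher number from compound 2 to compound 4 (0.59 log units; beyond the scatter). In this assay compound 4 is therefore estimated at 7000 nM. Given a single precedent, the likely range for compound 4 is kept wide, from 3000 nM to 18000 nM.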

Compound 4, half-maximal inhibitory concentration: 2800 nM
Estimate against measurement, compound 4: 2.5-fold (0.40 log units) above, outside the stated range (below it).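

In this assay the swap of methoxy to hydroxy on the core of compound 2 gives a 1.6-fold higher number from compound 2 to compound 4 (0.19 log units; within the scatter) and so, on this core, cannot be told apart from no change at all. Placed beside the earlier step, this looks like a smaller effect, yet the two steps cannot be separated from each other: the same change on two cores in this assay, a 4.1-fold higher number (0.62 log units; beyond the scatter) from compound 3 to compound 1 and a 1.6-fold higher number (0.19 log units; within the scatter) from compound 2 to compound 4, 2.7-fold (0.42 log units) apart, within the scatter of two such steps. The pairs therefore fit a single effect of similar size on both cores, but they do not prove one, and they do not show that the core alters the effect, since two pairs with this much scatter cannot settle either reading.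

The compounds shown leave open how this change would behave on a third core, which would offer a further test of whether it carries across the series. They also leave open what other groups would do at the same place on the aromatic ring, such as an ethoxy group with its longer chain, or an amine in place of the hydroxy.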